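A few compounds are considered here, and "the series" means these few. Any claim that something is new, unique, unknown or untested is made for them only; others in the source may bear on it.

Compound 1 `O=C(CCCCC(S)CCS)Nc1ccccc1` and compound 2 `O=C(CCCCC(S)CCS)Nc1ccccc1Cl` share a core and were both tested in a functional assay on Bel-7402 cells (Homo sapiens) for inhibition, read by MTT assay, with a stated time of 24 h, tested at 0.1 ug/mL; a higher number here means more inhibition of growth at the concentration tested, a lower number less inhibition of growth. In this assay compound 1 gives 0.85%, and compound 2 gives 5.11%. The change between them, (chloro in place of hydrogen on an aromatic carbon), made a step of a number 4.3 percentage points higher from compound 1 to compound 2 (within the scatter).

Compound 3 `O=C(CCCCC(S)CCS)Nc1ccccn1` differs from compound 1 by pyridin-2-yl in place of phenyl on an amide-type nitrogen. In this assay compound 3 gives "not active" (no number reported), reported only in those words, without a number.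

Compound 4 `O=C(CCCCC(S)CCS)Nc1ccc(Cl)cn1` has not been measured. It differs from compound 3 by chloro in place of hydrogen on an aromatic carbon. Within the data shown here, this is the same kind of change as the one from compound 1 to compound 2, but the place differs: in compound 2 the chloro sits on a six-membered aromatic ring of carbon only, ortho to a large group, whereas in compound 4 it sits on a six-membered aromatic ring with 1 nitrogen, two atoms from the ring nitrogen, para to a large group.

Among the measured compounds shown here, for compound 4 in this assay a step no larger than the one from compound 1 to compound 2 is expected, because a number 4.3 percentage points higher from compound 1 to compound 2 (within the scatter) lay within the scatter. With compound 3 reported as not active, compound 4 is expected to give about 4%, most likely between 0% and 14%.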

Compound 4, percent growth inhibition at one concentration: "not active" (no number reported)
For compound 4 the study gives words and no number; there is nothing to compare the estimate with.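

In this assay, among these compounds, compound 3 and compound 4 are both reported in words, without a number, so no step between them can be read. The compounds shown leave open whether chloro in place of hydrogen changes growth inhibition at all on this six-membered aromatic ring with 1 nitrogen. No further data shown here bear on this result.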